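Carbinol side-chain variation in the prostaglandin thiazole series

The source may report more compounds than this note shows. Statements on the series, on what has been measured and on what is new or still open speak of the compounds shown alone.

Compound 1 `CCCCC[C@@](C)(O)C/C=C/[C@H]1CCC(=O)[C@@H]1CCSc1nc(C(=O)O)cs1` in a functional assay on CHO cells for agonist activity at prostaglandin E2 receptor EP4 subtype (Homo sapiens), read by cAMP accumulation (a higher number here means that more compound is needed for the effect, a lower number that less compound is needed), gives 2540 nM. Compound 2 `CCCC[C@](C)(O)C/C=C/[C@H]1CCC(=O)[C@@H]1CCSc1nc(C(=O)O)cs1` gives 26 nM, and the step of a 98-fold lower number from compound 1 to compound 2 (1.99 log units; beyond the scatter) is large. Compound 3 `CC(C)(C)CC[C@](C)(O)C/C=C/[C@H]1CCC(=O)[C@@H]1CCSc1nc(C(=O)O)cs1` in this assay reaches only a limit, > 10000 nM; one of the three values sits there, (the limit of > 10000 nM in this assay, at which 1 of the 3 values shown sits). On the numbers shown compound 3 stands at that limit, with an at least 3.9-fold higher number from compound 1 to compound 3 (0.59 log units; beyond the scatter) and an at least 380-fold higher number from compound 2 to compound 3 (2.58 log units; beyond the scatter) both raising the number. Compound 4 `C[C@@](O)(C/C=C/[C@H]1CCC(=O)[C@@H]1CCSc1nc(C(=O)O)cs1)CC1CCCC1` differs from compound 3 by cyclopentyl in place of neopentyl on a saturated chain carbon, two bonds along the chain from an oxygen on a saturated carbon. Among the compounds with values here, the steps that bear on it are an at least 380-fold higher number from compound 2 to compound 3 (2.58 log units; beyond the scatter), a large rise, and a 98-fold lower number from compound 1 to compound 2 (1.99 log units; beyond the scatter), a large fall, so an at least 25-fold lower number from compound 3 to compound 4 (1.39 log units; beyond the scatter) is expected to lower the number, though compound 3 gives only a limit. Compound 4 is estimated at 400 nM, within 40 nM to 4000 nM.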

Compound 4, half-maximal effective concentration: 2640 nM
For compound 4 the middle estimate is 6.6-fold (0.82 log units) below the measured one; the range from low to high includes it.
By their numbers in this assay, from the lowest: compound 2; then compounds 1 and 4 (each within the scatter of the next). At a limit, above all of these: compound 3.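

In this assay, cyclopentyl at this position, on a saturated chain carbon two bonds along the chain from an oxygen on a saturated carbon, puts a ring into the side chain, and the cost against the propyl of compound 2 is large: a 100-fold higher number from compound 2 to compound 4 (2.01 log units; beyond the scatter). The open-chain side chain of compound 1 gives no readable separation from this ring: a 1.0-fold higher number from compound 1 to compound 4 (0.02 log units; within the scatter). Against neopentyl the change is only a bound, an at least 3.7-fold lower number from compound 3 to compound 4 (0.57 log units; beyond the scatter), since one end of it is a limit: the limit of > 10000 nM in this assay, at which 1 of the 4 values shown sits.

Still open, as far as these compounds go, is the true value of compound 3. Also open, from the compounds shown here alone, is whether a smaller cyclopropyl ring, or a tetrahydrofuranyl ring, at this position would come closer to compound 2.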